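Swapping the pyridazine arm for a cyanopyridine: expected stability

The compounds below may be only part of what the source reports. "The series", "measured", "known", "first", "only" and "open" are said of these compounds alone.

Measured so far:
compound 1, `COc1ccc(Nc2cc3[nH]c(-c4cccc(C(F)(F)F)c4)nc3cn2)nc1`: 32%
compound 2, `FC(F)(F)c1cccc(-c2nc3cnc(Nc4cccnn4)cc3[nH]2)c1`: 69%

In an ADME assay on microsomes from liver (Rattus norvegicus) for metabolic stability, read by LC-MS, with a stated time of 30 min, tested at 0.1 uM (on this read-out lower numbers stand for a less stable compound and higher numbers for a more stable compound), compound 2 stands highest of the two numbers; its nearest neighbour is compound 1, and the step of a number 37 percentage points higher from compound 1 to compound 2 (beyond the scatter) lies beyond the scatter. Compound 3, `N#Cc1ccc(Nc2cc3[nH]c(-c4cccc(C(F)(F)F)c4)nc3cn2)nc1`, is not yet measured. It differs from compound 2 by 5-cyanopyridin-2-yl in place of pyridazin-3-yl on a nitrogen on an aromatic ring. Going by the values given here, only the step from compound 1 to compound 2 bears on this change, and only partly, as compound 3 carries a 5-cyanopyridin-2-yl rather than the 5-methoxypyridin-2-yl of compound 1. Compound 3 is therefore expected to fall by a number 19 percentage points lower from compound 2 to compound 3 (beyond the scatter) in this assay, landing at an estimated 50% with a range from 28% to 74%.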

Compound 3, percent of the compound remaining: 49%
Estimate against measurement, compound 3: 1 percentage points above, and the stated range covers the measured number.
By their numbers in this assay, from the lowest: compound 1; then compound 3; then compound 2.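

Compound 3 shows that a pyridine arm on this nitrogen need not sit as low as the methoxy one: in this assay, cyano in place of methoxy on an aromatic carbon gives a number 17 percentage points higher from compound 1 to compound 3 (beyond the scatter) and so closes part of the gap to the pyridazine. Yet 5-cyanopyridin-2-yl in place of pyridazin-3-yl still gives a number 20 percentage points lower from compound 2 to compound 3 (beyond the scatter) on the same read-out. No measurement shown explains either step.

Open, going by these compounds, is how a fluorine or an amide in place of the cyano would read on this pyridine. Also open, on these data alone, is whether a cyano on the pyridazine ring would raise or lower its number.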